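Methylsulfonyl in place of methoxy on the chain carbon

The compounds below may be only part of what the source reports. "The series", "measured", "known", "first", "only" and "open" are said of these compounds alone.

Three compounds have been measured in a functional assay on the whole organism (stomach) for inhibition, with Canis familiaris (Canis lupus familiaris) as the target, at a dose of 5 mg/kg by the intravenous route; a higher number here means a stronger effect of the compound at the dose given, a lower number a weaker effect:
compound 1 `Cc1cn2cccc(OCc3ccccc3)c2n1` gives 70%
compound 2 `Cc1nc2c(OCc3ccccc3)cccn2c1CCC#N` gives 20%
compound 3 `COCc1c(C)nc2c(OCc3ccccc3)cccn12` gives 29%

Compound 3 stands second highest of the three. Its nearest neighbour is compound 2, and the step of a number 9 percentage points higher from compound 2 to compound 3 (within the scatter) lies within the scatter, so the two cannot be told apart. Compound 1 is the clear outlier, standing higher than compound 3 by a number 41 percentage points lower from compound 1 to compound 3 (beyond the scatter) and above compound 2 by a number 50 percentage points lower from compound 1 to compound 2 (beyond the scatter), both beyond the scatter; in each of those steps a group entered on an aromatic carbon of the shared core where compound 1 carries hydrogen.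

Compound 4 `Cc1nc2c(OCc3ccccc3)cccn2c1CS(C)(=O)=O` is not yet measured. It differs from compound 3 by methylsulfonyl in place of methoxy on a saturated chain carbon bound to an aromatic carbon. Among the compounds with values here, the one measured step that touches this same chain carbon is a number 9 percentage points higher from compound 2 to compound 3 (within the scatter), which stayed within the scatter when the group on that carbon was exchanged. The large drops belong to the other site and do not bear directly on this change. The expectation for this assay is therefore a step of a number 1 percentage points higher from compound 3 to compound 4 (within the scatter), no change beyond the scatter. Compound 4 is estimated at 30%, within the range 10% to 55%.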

Compound 4, a percentage reported as inhibition, in the whole organism at one dose (the size of the read-out at that dose, not a potency): 0%
The estimate for compound 4 lay 30 percentage points above the measured number, and the stated range ends above it.
By their numbers in this assay, from the lowest: compound 4; then compounds 2 and 3 (each within the scatter of the next); then compound 1.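

In this assay, the group on this saturated chain carbon proves to matter: the earlier exchange of cyanomethyl for methoxy stayed within the scatter, whereas methylsulfonyl gives a number 29 percentage points lower from compound 3 to compound 4 (beyond the scatter) and a number 20 percentage points lower from compound 2 to compound 4 (beyond the scatter). Set against the compound that carries hydrogen on the aromatic carbon, the whole (methylsulfonyl)methyl group gives a number 70 percentage points lower from compound 1 to compound 4 (beyond the scatter), so all three groups placed there go with a lower number than hydrogen, and compound 4 reads lowest of the series. The data offer no measurement that accounts for this difference between methylsulfonyl and methoxy.

The compounds shown leave open whether the loss belongs to the methylsulfonyl group in particular or would also appear with a methylthio group, an amine or a carboxylic acid on the same chain carbon, and whether any group there could match compound 1 at 70%. They also leave open how the compounds compare in potency, since this assay reports the size of the effect at a single dose.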